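Carbamate ester variation on the shared core

This account rests on a few compounds, and the source may have more. Where it says the series, first, only, none or still open, it means among the compounds named here.

Measured compounds in a functional assay on isolated protein for inhibition of Glucose-dependent insulinotropic receptor (Homo sapiens), read by HTRF and cAMP accumulation; on this read-out higher numbers stand for an effect only at larger amounts of compound and lower numbers for an effect already at smaller amounts:
compound 1 `Cc1nc(S(C)(=O)=O)ccc1Oc1ncnc(OC2CCN(C(=O)OC3CCC3)CC2)c1F` gives 13.6 nM
compound 2 `Cc1nc(S(C)(=O)=O)ccc1Oc1ncnc(OC2CCN(C(=O)O[C@H](C)CF)CC2)c1F` gives 196 nM
compound 3 `Cc1nc(S(C)(=O)=O)ccc1Oc1ncnc(OC2CCN(C(=O)O[C@@H](C)CF)CC2)c1F` gives 186 nM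

Compound 3 stands second highest of the three numbers, within the scatter of compound 2 and far from compound 1. The step to compound 4 `Cc1nc(S(C)(=O)=O)ccc1Oc1ncnc(OC2CCN(C(=O)O[C@H](C)C(F)(F)F)CC2)c1F` is 1-(trifluoromethyl)ethyl in place of 1-(fluoromethyl)ethyl on an oxygen next to a carbonyl group. Among the compounds with values here, two measured steps bear on this position. Exchange of the whole ester group was large: a 14-fold higher number from compound 1 to compound 3 (1.14 log units; beyond the scatter). The configuration at that position alone did not matter, a 1.1-fold lower number from compound 2 to compound 3 (0.02 log units; within the scatter), consistent with the fact that compounds 2 and 3 differ only in the configuration as drawn. Within the data shown here, no measured step swaps fluoromethyl for trifluoromethyl, so only a modest change is expected: a 1.2-fold lower number from compound 3 to compound 4 (0.09 log units; within the scatter), direction uncertain. Compound 4 is estimated at 150 nM, range 50 nM to 450 nM.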

Compound 4, half-maximal effective concentration: 9.2 nM
Compound 4: the middle estimate sits 16-fold (1.21 log units) above what was measured; measured number outside the range, below it.
By their numbers in this assay, from the lowest: compounds 4 and 1 (each within the scatter of the next); then compounds 3 and 2 (each within the scatter of the next).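

Trifluoromethyl and fluoromethyl are far from interchangeable on this ester group, a difference the earlier compounds could not reveal: the change gives a 20-fold lower number from compound 3 to compound 4 (1.31 log units; beyond the scatter), and likewise a 21-fold lower number from compound 2 to compound 4 (1.33 log units; beyond the scatter). An open-chain group can also stand level with cyclobutyl at this position, with a 1.5-fold lower number from compound 1 to compound 4 (0.17 log units; within the scatter). Nothing measured here accounts for the size of this change.

As far as these compounds go, it remains open whether the opposite configuration of 1-(trifluoromethyl)ethyl reads like compound 4, and how a difluoromethyl group or a longer chain would read on this oxygen.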